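A few compounds are considered here, and "the series" means these few. Any claim that something is new, unique, unknown or untested is made for them only; others in the source may bear on it.

Compound 1 `Cc1ccc(C)c(OCc2nnc(C(=O)Nc3ccc(CCC(=O)O)cc3)s2)c1` gives 1530 nM in a functional assay on CHO cells for agonist activity at Free fatty acid receptor 1 (Homo sapiens), read by FLIPR and calcium flux, tested at 1 uM; on this read-out lower numbers stand for an effect already at smaller amounts and higher numbers for an effect only at larger amounts of compound; compound 2 `Cc1ccc(OCc2nnc(C(=O)Nc3ccc(CCC(=O)O)cc3)s2)c(C)c1` gives 2540 nM in this assay; compound 3 `CCc1ccc(OCc2nnc(C(=O)Nc3ccc(CCC(=O)O)cc3)s2)cc1` gives 1170 nM in this assay.

Compound 3 has the lowest of the three numbers, yet its gap to compound 1 lies within the scatter, while the step of a 2.2-fold lower number from compound 2 to compound 3 (0.34 log units; beyond the scatter) is beyond it. Compound 4 `O=C(O)CCc1ccc(NC(=O)c2nnc(Cc3ccccc3)s2)cc1` carries phenyl in place of 4-ethylphenoxy on a saturated chain carbon bound to an aromatic carbon. Among the measured compounds shown here, no measured step removes the oxygen; the steps that only exchange the aryl group on it, a 1.3-fold lower number from compound 1 to compound 3 (0.12 log units; within the scatter) and a 2.2-fold lower number from compound 2 to compound 3 (0.34 log units; beyond the scatter), were small. The change to compound 4 reaches further than either of them, so a modest rise in the number is expected, a 2.7-fold higher number from compound 3 to compound 4 (0.44 log units; beyond the scatter), with wide uncertainty. Compound 4 is therefore estimated at 3200 nM, between 1000 nM and 10000 nM.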

Compound 4, half-maximal effective concentration: 3670 nM
For compound 4 the middle estimate is 1.1-fold (0.06 log units) below the measured one; the range from low to high includes it.
By their numbers in this assay, from the lowest: compounds 3, 1, 2 and 4 (each within the scatter of the next, the first and the last beyond it).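

Replacing the substituted phenoxy groups with phenyl on a saturated chain carbon bound to an aromatic carbon gives only modest rises, with a 3.1-fold higher number from compound 3 to compound 4 (0.50 log units; beyond the scatter) and a 2.4-fold higher number from compound 1 to compound 4 (0.38 log units; beyond the scatter) as the two steps beyond the scatter. Set against the third ether, the change shows a 1.4-fold higher number from compound 2 to compound 4 (0.16 log units; within the scatter) and so cannot be told apart from it. The oxygen and the ring substituents can therefore go together while the number stays in the range of the ethers, though no evidence at hand explains these steps. Going by these compounds, how much of the change belongs to the oxygen and how much to the ring substituents stays open, and a plain phenoxy group or an amine in place of the oxygen would separate the two.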